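Chlorophenyl change from compound 1 to compound 3

A few compounds are considered here, and "the series" means these few. Any claim that something is new, unique, unknown or untested is made for them only; others in the source may bear on it.

- compound 1 `CN1CCN(CCCOc2cccc3nc(Nc4ccc(Cl)c(C(F)(F)F)c4)ccc23)CC1` gives 6980 nM
- compound 2 `CN1CCN(CCCOc2cccc3nc(Nc4cc(Cl)cc(Cl)c4)ccc23)CC1` gives 6200 nM

Among the measured compounds shown here, in a functional assay on cells (Panel CNS (Carcinoma cell lines), Homo sapiens) for inhibition, read by sulforhodamine B assay, with a stated time of 48 h (on this read-out lower numbers stand for higher toxicity in this test and higher numbers for lower toxicity in this test), compound 1 and compound 2 lie within the scatter of each other, so compound 1 stands level with the only other measured compound. The change to compound 3 `CN1CCN(CCCOc2cccc3nc(Nc4cccc(Cl)c4)ccc23)CC1` is 3-chlorophenyl in place of 4-chloro-3-(trifluoromethyl)phenyl on a nitrogen on an aromatic ring with the shared core unchanged. For the measured compounds named here, the one measured step at this place is a 1.1-fold lower number from compound 1 to compound 2 (0.05 log units; within the scatter) and it stays within the scatter. In this assay no step beyond the scatter is therefore expected. The expected step is a 1.0-fold higher number from compound 1 to compound 3 (0.00 log units; within the scatter) on this estimate. For compound 3 the estimated value is 7000 nM with an expected range from 3800 nM to 13000 nM in this read-out.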

Compound 3, concentration lethal to 50% of the cells: 23300 nM
Compound 3: the middle estimate sits 3.3-fold (0.52 log units) below what was measured; the whole stated range lies below it.
By their numbers in this assay, from the lowest: compounds 2 and 1 (each within the scatter of the next); then compound 3.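

In this assay, this position proves sensitive after all: the 3-chlorophenyl gives a 3.3-fold higher number from compound 1 to compound 3 (0.52 log units; beyond the scatter), and hydrogen in place of chloro on an aromatic carbon gives a 3.8-fold higher number from compound 2 to compound 3 (0.57 log units; beyond the scatter), each towards lower toxicity in this test. Among these compounds, the two with a second group on the phenyl ring stand level, while compound 3, with chloro alone, stands apart. No measurement given here bears on the reason for this. As far as these compounds go, whether a plain phenyl would raise the number further remains open, as does the effect of a methoxy group or a nitrile in place of the chloro.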